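The compounds below may be only part of what the source reports. "The series", "measured", "known", "first", "only" and "open" are said of these compounds alone.

Compound 1 `CC(=O)OC[C@H]1OC(n2cc(C3OCCO3)c(=O)[nH]c2=O)C[C@@H]1OC(C)=O` gives a limit of > 300000 nM in a functional assay on HFF cells (Homo sapiens) for cytotoxicity, read by neutral red uptake; a higher number here means that more compound is tolerated, a lower number that less compound is tolerated.
Compound 2 `O=c1[nH]c(=O)n(C2C[C@H](O)[C@@H](CO)O2)cc1C1OCCO1` gives a limit of > 300000 nM in this assay.
Compound 3 `CC(=O)OC[C@H]1OC(n2cc(C3OCCCO3)c(=O)[nH]c2=O)C[C@@H]1OC(C)=O` gives a limit of > 300000 nM in this assay.

All three values sit at the limit of > 300000 nM in this assay, at which 3 of the 3 values shown sit, so none is a number. The step from compound 1 to compound 3 is a step that the two limits leave unreadable from compound 1 to compound 3; it is a group of 6 heavy atoms (4 carbon, 2 oxygen; one six-membered non-aromatic ring with 2 hetero atoms) in place of a group of 5 heavy atoms (3 carbon, 2 oxygen; one five-membered non-aromatic ring with 2 hetero atoms), on an aromatic carbon. Compound 4 `O=c1[nH]c(=O)n(C2C[C@H](O)[C@@H](CO)O2)cc1C1OCCCO1`, not yet measured, differs from compound 2 by a group of 6 heavy atoms (4 carbon, 2 oxygen; one six-membered non-aromatic ring with 2 hetero atoms) in place of a group of 5 heavy atoms (3 carbon, 2 oxygen; one five-membered non-aromatic ring with 2 hetero atoms), on an aromatic carbon. Among the measured compounds shown here, this is the same kind of change as the one between compound 1 and compound 3. The difference between the cores of compound 1 and compound 2 is not broken down here. Because compound 1 and compound 3 both sit at the limit of > 300000 nM in this assay, at which 3 of the 3 values shown sit, the expected step is a step that the limit leaves unreadable from compound 2 to compound 4 in this assay, set beside a step that the two limits leave unreadable from compound 1 to compound 3. In this assay compound 4 is therefore expected to give 400000 nM, within 200000 nM to 1000000 nM, most likely reported again as a limit.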

Compound 4, half-maximal cytotoxic concentration: > 300000 nM
Compound 4 gave a limit, no number; the forecaster's own chance of this, stated with the estimate: 85%; the middle value is on the limit's open side.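

Among the compounds shown here, compound 2 and compound 4 are both limits rather than numbers, so no step between them can be read: the limit of > 300000 nM in this assay, at which 4 of the 4 values shown sit. The compounds shown leave open at what concentration any of them turns cytotoxic in this assay.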